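Rearranging the amide side chain of compound 3

The source may hold more compounds than are shown below. What is called first, only, known or untested is meant among the compounds shown, and "the series" means these compounds.

Values in an ADME assay on microsomes from liver (Mus musculus, strain CD-1) for metabolic stability, read by LC-MS, tested at 2 uM (a lower number here means that the compound disappears faster, a higher number that the compound lasts longer), so far
Compound 1 `Cn1cc(CNC(=O)c2ccncc2Nc2cc(-c3ccc4ccn(C)c4c3)c3nccnc3c2)cn1` gives 0.267 h
Compound 2 `Cn1ccc2ccc(-c3cc(Nc4cnccc4C(=O)NC4CCNC(=O)C4)cc4nccnc34)cc21` gives > 1 h
Compound 3 `CN1CCC(CNC(=O)c2ccncc2Nc2cc(-c3ccc4ccn(C)c4c3)c3nccnc3c2)C1` gives > 1 h

Compound 3 is known only as a limit (> 1 h). Compound 2 is also known only as a limit (> 1 h). The measurements here end at the limit of > 1 h in this assay, at which 2 of the 3 values shown sit, and give no number beyond it. The comparison of these two shows a step that the two limits leave unreadable from compound 2 to compound 3 and no order.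

Compound 4 `CN1CCC(N(C)C(=O)c2ccncc2Nc2cc(-c3ccc4ccn(C)c4c3)c3nccnc3c2)C1` has the same atoms as compound 3, joined differently (methyl(1-methylpyrrolidin-3-yl)amino in place of ((1-methylpyrrolidin-3-yl)methyl)amino on a carbonyl carbon). It keeps the five-membered non-aromatic ring that came in with an at least 3.7-fold higher number from compound 1 to compound 3 (0.57 log units; beyond the scatter) and so no change beyond the scatter is expected in this assay here. Another change on the same amide nitrogen gave an at least 3.7-fold higher number from compound 1 to compound 2 (0.57 log units; beyond the scatter) and neither measured step tests a swap of this kind. The estimated step is a number no higher from compound 3 to compound 4 (the limit leaves the size open) and it remains uncertain. For compound 4 the estimate is 1 h (expected range 0.4 h to 3 h).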

Compound 4, half-life in the Mus musculus assay: > 1 h
Compound 4 gave a limit, no number; the forecaster's own chance of this, stated with the estimate: 50%; the middle value sits exactly at the limit.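

In the Mus musculus assay compound 4 gives > 1 h, which is a limit and not a number. In the Mus musculus assay the methyl(1-methylpyrrolidin-3-yl)amino group, with 0 hydrogen-bond donors, still gives an at least 3.7-fold higher number from compound 1 to compound 4 (0.57 log units; beyond the scatter), so this reading does not need the amide hydrogen. In a physicochemical assay for solubility, read by spectrophotometry, measured as kinetic solubility, at pH 8, tested at 500 uM (on this read-out higher numbers stand for higher solubility and lower numbers for lower solubility), compound 3 gives 246 ug/mL and compound 4 gives 245 ug/mL. In the physicochemical assay the same rearrangement gives a 1.0-fold lower number from compound 3 to compound 4 (0.00 log units; within the scatter), so the two compounds show no difference there. Back in the Mus musculus assay, the steps to compound 4 from compound 2 and from compound 3 cannot be read because these compounds all stand at one limit: the limit of > 1 h in the Mus musculus assay, at which 3 of the 4 values shown sit.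

Going by these compounds, whether compound 3 and compound 4 differ in half-life therefore stays open. Also open, on these data alone, is whether a longer chain on the amide nitrogen, or a morpholine ring in place of the 1-methylpyrrolidin-3-yl ring, would keep this reading.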